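Working notes: oxazolidinone series, lipophilicity step to compound 3

The source may hold more compounds than are shown below. What is called first, only, known or untested is meant among the compounds shown, and "the series" means these compounds.

Measured in a physicochemical assay for lipophilicity, read by HPLC, measured as octanol-water partition; on this read-out higher numbers stand for higher lipophilicity and lower numbers for lower lipophilicity:
Compound 1 `O=C1CSC(=O)N1C[C@H]1CN(c2ccc(-n3cc(-c4ccccn4)cn3)c(F)c2)C(=O)O1`: compound 1 gives 2.18.
Compound 2 `O=C(OC[C@H]1CN(c2ccc(-n3cc(-c4ccccn4)cn3)c(F)c2)C(=O)O1)c1ccccc1`: compound 2 gives 4.21.

Compound 2 stands highest of the two numbers in this assay. Going by the values given here, the single step in hand, a number 2.03 log units higher from compound 1 to compound 2 (beyond the scatter), is large and falls at the same place as the change now considered. Compound 3 `O=C(NC[C@H]1CN(c2ccc(-n3cc(-c4ccccn4)cn3)c(F)c2)C(=O)O1)C(F)F` differs from compound 2 as follows: ((difluoromethyl)carbonyl)amino in place of benzoyloxy on a saturated chain carbon bound to a saturated ring carbon. Among the compounds with values here, since the only known step shows a large rise when the ring-free group left and benzoyloxy entered, a large fall in this assay is expected when benzoyloxy leaves again: a number 2.11 log units lower from compound 2 to compound 3 (beyond the scatter). For compound 3 in this assay the estimated value is 2.1, with a range of 1.5 to 2.7.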

Compound 3, partition coefficient: 1.9
Compound 3: the middle estimate sits 0.20 log units above what was measured; low and high end bracket the measured number.
By their numbers in this assay, from the lowest: compounds 3 and 1 (each within the scatter of the next); then compound 2.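

In this assay, ((difluoromethyl)carbonyl)amino in place of benzoyloxy on a saturated chain carbon bound to a saturated ring carbon gives a second large step at this position (a number 2.31 log units lower from compound 2 to compound 3 (beyond the scatter)). Against 2,4-dioxo-1,3-thiazolidin-3-yl, the same group shows no separation (a number 0.28 log units lower from compound 1 to compound 3 (within the scatter)), so two structurally unlike groups read alike and, of the three groups, benzoyloxy alone stands apart.

From the compounds shown here alone, whether an amine, a carboxylic acid or a longer chain at this position would read with compound 1 and compound 3 or with compound 2 remains open. No measurement at hand accounts for these steps.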